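A few compounds are considered here, and "the series" means these few. Any claim that something is new, unique, unknown or untested is made for them only; others in the source may bear on it.

Compound 2, `CN(CCCn1cc[n+](C)c1/C=N/O)S(=O)(=O)C(F)(F)F`, is the more lipophilic of the two measured compounds: in a physicochemical assay for lipophilicity (on this read-out higher numbers stand for higher lipophilicity and lower numbers for lower lipophilicity), compound 2 gives -1.37. Compound 1, `CCN(CCCn1cc[n+](C)c1/C=N/O)S(C)(=O)=O`, differs from it in more than one place; in this assay compound 1 gives -2.69, a number well below that of compound 2. Compound 3, `CCN(CCCn1cc[n+](C)c1/C=N/O)S(=O)(=O)C(F)(F)F`, has not been measured. It differs from compound 2 by methyl in place of hydrogen on a saturated chain carbon bound to a sulfonamide nitrogen. Compound 3 is expected to show a small rise in this assay, with an estimated step of a number 0.37 log units higher from compound 2 to compound 3 (beyond the scatter), modest but possibly beyond the scatter. Compound 3 is therefore estimated at -1, within a range from -1.4 to -0.6.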

Compound 3, distribution coefficient: -1.02
Estimate against measurement, compound 3: 0.02 log units above; the range from low to high includes it.
By their numbers in this assay, from the lowest: compound 1; then compound 2; then compound 3.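

In this assay, among these compounds, methyl in place of hydrogen on a saturated chain carbon bound to a sulfonamide nitrogen gives a modest step (a number 0.35 log units higher from compound 2 to compound 3 (beyond the scatter)), the first reading of a change at this position. Compound 3 also isolates the sulfonyl sulfur, where trifluoromethyl in place of methyl gives a large step (a number 1.67 log units higher from compound 1 to compound 3 (beyond the scatter)). No evidence here accounts for either step. On these data alone, whether a longer chain such as propyl in the first place would extend the rise remains open, as does how a phenyl group on the sulfonyl sulfur would read.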